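The source may hold more compounds than are shown below. What is called first, only, known or untested is meant among the compounds shown, and "the series" means these compounds.

Measured so far:
- compound 1, `Cc1cccc2sc(NN)nc12`: 9.8 ug/mL
- compound 2, `NNc1nc2c([N+](=O)[O-])cccc2s1`: 14.5 ug/mL
- compound 3, `O=[N+]([O-])c1ccc(-c2nnc(-c3cccnc3)n2Nc2nc3ccc([N+](=O)[O-])cc3s2)cc1`: 50.8 ug/mL

All three were tested in an ADME assay on MT4 cells (Homo sapiens) for cytotoxicity, read by MTT assay, with a stated time of 5 days; on this read-out lower numbers stand for higher toxicity in this test and higher numbers for lower toxicity in this test. Compound 2 and compound 1 differ in one place, (methyl in place of nitro on an aromatic carbon), and the step of a 1.5-fold lower number from compound 2 to compound 1 (0.17 log units; within the scatter) is small. Compound 3 gives the highest number of the three; how its core differs from the core of compound 2 is not broken down here.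

Compound 4, `Cc1ccc2nc(Nn3c(-c4ccc([N+](=O)[O-])cc4)nnc3-c3cccnc3)sc2c1`, has not yet been measured. It differs from compound 3 by methyl in place of nitro on an aromatic carbon. This is the same kind of change as from compound 2 to compound 1, though not at the same place: in compound 2 the group sits ortho to a fused ring and meta to a fused ring, in compound 3 meta to a fused ring and para to a fused ring.

Because a 1.5-fold lower number from compound 2 to compound 1 (0.17 log units; within the scatter) stayed within the scatter, a step of similar size is expected here, a 1.3-fold lower number from compound 3 to compound 4 (0.10 log units; within the scatter). Compound 4 is therefore expected to give about 40 ug/mL in this assay, likely between 15 ug/mL and 100 ug/mL.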

Compound 4, half-maximal cytotoxic concentration: 64.4 ug/mL
The estimate for compound 4 lay 1.6-fold (0.21 log units) below the measured number; low and high end bracket the measured number.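

In this assay, putting methyl in place of nitro on an aromatic carbon gives a 1.3-fold higher number from compound 3 to compound 4 (0.10 log units; within the scatter), so on this larger core the exchange leaves the number inside the normal spread of repeated measurements. Set beside the earlier case, the two steps agree within that spread: the same change on two cores in this assay, a 1.5-fold lower number (0.17 log units; within the scatter) from compound 2 to compound 1 and a 1.3-fold higher number (0.10 log units; within the scatter) from compound 3 to compound 4, 1.9-fold (0.27 log units) apart, within the scatter of two such steps This shows that in these two pairs the exchange carried over from one core to the other without a change in the number that stands out from the scatter, even though the nitro group sits at a different place on each core; it does not show a real direction for the change, since both steps are too small to read as a rise or a fall, and two pairs say nothing about other cores.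

The compounds shown leave open whether an amine, a carboxylic acid or a longer chain on that aromatic carbon would also stay within the scatter. They also leave open what exchanging the nitro group that remains in compound 4 would do.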